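Aryl swap on the saturated ring carbon: compound 3

The source may hold more compounds than are shown below. What is called first, only, known or untested is meant among the compounds shown, and "the series" means these compounds.

The series shares one core. Compound 1 `CCCC1C(=O)N(C)c2cnc(Nc3ccc(S(N)(=O)=O)cc3)nc2N1C` carries a propyl on the saturated ring carbon, and in an assay on Sf9 cells for inhibition of serine/threonine-protein kinase 4 (Homo sapiens), read by luminescence and ADP-Glo, with a stated time of 1 h, in the presence of a further agent that is not named here (on this read-out lower numbers stand for stronger inhibition and higher numbers for weaker inhibition), compound 1 gives 206 nM. Within the data shown here, compound 2 `CN1C(=O)C(c2cccc(Cl)c2)N(C)c2nc(Nc3ccc(S(N)(=O)=O)cc3)ncc21` carries a 3-chlorophenyl at the same place; in this assay compound 2 gives 989 nM, the highest of the two numbers so far, a standing set by the only measured step, a 4.8-fold higher number from compound 1 to compound 2 (0.68 log units; beyond the scatter). Compound 3 `CN1C(=O)C(c2c(F)cccc2F)N(C)c2nc(Nc3ccc(S(N)(=O)=O)cc3)ncc21` is the next entry: 2,6-difluorophenyl in place of 3-chlorophenyl on a saturated ring carbon. Among the measured compounds shown here, no measured step exchanges one aryl group for another; the single step at this position took a propyl to a 3-chlorophenyl and offers little guidance for a change between two aryl groups. The expected step of a 1.2-fold lower number from compound 2 to compound 3 (0.09 log units; within the scatter) is therefore small, with no direction claimed beyond the scatter. Compound 3 is estimated at 800 nM, within a range from 250 nM to 2500 nM.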

Compound 3, half-maximal inhibitory concentration: 42 nM
The estimate for compound 3 lay 19-fold (1.28 log units) above the measured number; measured number outside the range, below it.
By their numbers in this assay, from the lowest: compound 3; then compound 1; then compound 2.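

Among these compounds, exchanging one aryl group for another on the saturated ring carbon is not a minor change in this assay: 2,6-difluorophenyl in place of 3-chlorophenyl gives a 24-fold lower number from compound 2 to compound 3 (1.37 log units; beyond the scatter), the largest step at this position so far. An aryl group as such therefore does not go with a higher number than propyl: 3-chlorophenyl lies above the propyl compound, whereas 2,6-difluorophenyl in place of propyl gives a 4.9-fold lower number from compound 1 to compound 3 (0.69 log units; beyond the scatter), so the two aryl groups fall on opposite sides of compound 1. The data shown offer nothing that accounts for this difference between the two aryl groups.

Still open, on these data alone, is whether an unsubstituted phenyl or a phenyl with a single fluorine would fall nearer compound 3 or compound 2. Also open, as far as these compounds go, is how a longer chain than propyl, or a chain ending in an amine, would compare at this carbon.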